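Series notes: the step from compound 3 to compound 4

The source may hold more compounds than are shown below. What is called first, only, known or untested is meant among the compounds shown, and "the series" means these compounds.

Among the compounds with values here, compound 1 `CN(C)Cc1ccc(-n2cc(-c3ccc4cc[nH]c4c3)c3c(Cl)ccnc32)cc1` is the only member with a numerical reading: in an assay on isolated protein for inhibition of thyroid peroxidase (Homo sapiens) (on this read-out lower numbers stand for stronger inhibition and higher numbers for weaker inhibition), compound 1 gives 5300 nM. Compound 2 `NCc1ccc(-n2cc(-c3ccc4cc[nH]c4c3)c(C(F)(F)F)n2)cc1` reaches only a limit of this assay, compound 2 giving > 30000 nM. Compound 3 `NC(=O)CCn1cc(-c2ccc3cc[nH]c3c2)c(C(F)(F)F)n1` likewise sits at a limit, compound 3 giving > 30000 nM in this assay. The step that the two limits leave unreadable from compound 2 to compound 3 is thus unreadable, and compound 3 stands at the limit of > 30000 nM in this assay, at which 2 of the 3 values shown sit, with nothing to place it further.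

Compound 4 `N[C@@H]1CC[C@@H](n2cc(-c3ccc4cc[nH]c4c3)c(C(F)(F)F)n2)C1` differs from compound 3 by a group of 6 heavy atoms (5 carbon, 1 nitrogen; one five-membered non-aromatic ring of carbon only) in place of a group of 5 heavy atoms (3 carbon, 1 nitrogen, 1 oxygen; no ring), on an aromatic nitrogen. Within the data shown here, no measured step bears on this change with a readable size, since the limit of > 30000 nM in this assay, at which 2 of the 3 values shown sit, covers both close analogues. Compound 4 is therefore expected to remain near that limit, estimated at 30000 nM with a range of 8000 nM to 100000 nM. The expected step of a number no higher from compound 3 to compound 4 (the limit leaves the size open) is accordingly not beyond the scatter.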

Compound 4, half-maximal inhibitory concentration: > 30000 nM
Compound 4: a limit, no number; the forecaster's own chance of this, stated with the estimate: 65%; the middle value sits exactly at the limit.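

In this assay, within the data shown here, compound 4 gives > 30000 nM, a limit, and no step among compound 2, compound 3 and compound 4 can be read. The compounds shown leave open how the group on the aromatic nitrogen bears on this read-out: the limit of > 30000 nM in this assay, at which 3 of the 4 values shown sit.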